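The source may report more compounds than this note shows. Statements on the series, on what has been measured and on what is new or still open speak of the compounds shown alone.

In an assay on isolated protein for inhibition of Indoleamine 2,3-dioxygenase 2 (Homo sapiens) (on this read-out higher numbers stand for weaker inhibition and lower numbers for stronger inhibition), the measured members of the series stand as follows:

compound 1 `OCc1cn(CCNc2nonc2/C(=N/O)Nc2ccc(F)c(Br)c2)nn1` gives 794 nM
compound 2 `OCCCc1cn(CCNc2nonc2/C(=N/O)Nc2ccc(F)c(Br)c2)nn1` gives 958 nM
compound 3 `CC(C)(O)c1cn(CCNc2nonc2/C(=N/O)Nc2ccc(F)c(Br)c2)nn1` gives 726 nM

Compound 2 carries the highest number of the three, yet the steps around it, a 1.2-fold higher number from compound 1 to compound 2 (0.08 log units; within the scatter) and a 1.3-fold lower number from compound 2 to compound 3 (0.12 log units; within the scatter), both lie within the scatter, so the three compounds are not separated by these numbers.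

Compound 4 `CC(C)CC(C)(O)c1cn(CCNc2nonc2/C(=N/O)Nc2ccc(F)c(Br)c2)nn1` is not yet measured. It differs from compound 2 in one place: 1-hydroxy-1,3-dimethylbutyl in place of 3-hydroxypropyl on an aromatic carbon

Within the data shown here, the steps that bear on this are those that exchange one hydroxy-bearing chain for another on the same aromatic carbon: a 1.1-fold lower number from compound 1 to compound 3 (0.04 log units; within the scatter) and a 1.3-fold lower number from compound 2 to compound 3 (0.12 log units; within the scatter), to which a 1.2-fold higher number from compound 1 to compound 2 (0.08 log units; within the scatter) adds a third exchange of the same kind. None of them moves the number beyond the scatter, so for compound 4 no step beyond the scatter is expected in this assay; the estimated step is a 1.2-fold lower number from compound 2 to compound 4 (0.07 log units; within the scatter). The value estimated for compound 4 is 820 nM, with a range from 400 nM to 1700 nM.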

Compound 4, half-maximal inhibitory concentration: 689 nM
Beside the measured number, compound 4's estimate is 1.2-fold (0.08 log units) above it, within the range that was stated.
By their numbers in this assay, from the lowest: compounds 4, 3, 1 and 2 (each within the scatter of the next).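

In this assay, the aromatic carbon of the five-membered aromatic ring with 3 nitrogen carries the 1-hydroxy-1,3-dimethylbutyl group, of 7 heavy atoms, with no step beyond the scatter against any earlier compound (a 1.4-fold lower number from compound 2 to compound 4 (0.14 log units; within the scatter)) (a 1.1-fold lower number from compound 3 to compound 4 (0.02 log units; within the scatter)) (a 1.2-fold lower number from compound 1 to compound 4 (0.06 log units; within the scatter)). The earlier compounds shown here covered only smaller hydroxy-bearing groups, so the flat read-out at this position now extends to a larger, branched chain, including the isopropyl added on the saturated chain of compound 3 to give compound 4. No supporting measurement bears on why the number stays flat across these groups.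

As far as these compounds go, all four compounds keep a hydroxy group on the chain, so whether that oxygen matters remains open. An amine or a carboxylic acid in its place, or a plain butyl chain, would test this position more sharply.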